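A few compounds are considered here, and "the series" means these few. Any claim that something is new, unique, unknown or untested is made for them only; others in the source may bear on it.

Working notes on the series. The shared core of compound 1 `O=C(O)CC(Cc1nc2cc(F)ccc2[nH]1)c1ccc(Cl)cc1` carries a fluoro group on an aromatic carbon; in an assay on isolated protein for inhibition of protein kinase C zeta type (Homo sapiens), read by 33P incorporation, tested at 50 uM (on this read-out higher numbers stand for a stronger effect at the one concentration tested and lower numbers for a weaker effect), compound 1 gives 0%. Compound 2 `Cc1ccc2[nH]c(CC(CC(=O)O)c3ccc(Cl)cc3)nc2c1` carries a methyl in place of the fluoro, and in this assay compound 2 gives 0%. Compound 3 `COC(=O)c1ccc2[nH]c(CC(CC(=O)O)c3ccc(Cl)cc3)nc2c1` carries a methoxycarbonyl at the same aromatic carbon, and in this assay compound 3 gives 0%. Compound 2 stands level with compound 1 and compound 3 on these numbers: no change at the digits printed from compound 1 to compound 2 (within the scatter), no change at the digits printed from compound 1 to compound 3 (within the scatter), no change at the digits printed from compound 2 to compound 3 (within the scatter). Every exchange at this aromatic carbon so far has left the read-out where it was.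

Compound 4 `N#Cc1ccc2[nH]c(CC(CC(=O)O)c3ccc(Cl)cc3)nc2c1` is not yet measured; it differs from compound 2 as follows. cyano in place of methyl on an aromatic carbon The three steps that bear on it all fall within the scatter, so no step beyond the scatter is expected in this assay in either direction; the step from compound 2 to compound 4 is expected as no change at the digits printed from compound 2 to compound 4 (within the scatter). For compound 4 the expected value in this assay is 0%, with a range from -10% to 12%.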

Compound 4, a percentage reported as inhibition, at one concentration (the size of the read-out at that concentration, not a potency): 0%
Compound 4: middle estimate and measured number agree at the digits printed, within the range that was stated.
By their numbers in this assay, from the lowest: compounds 1, 2, 3 and 4 (each within the scatter of the next).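

In this assay, among these compounds, the cyano group, the first group here to bring a triple bond and a hydrogen-bond acceptor to this aromatic carbon, leaves the read-out as the earlier groups did: no change at the digits printed from compound 2 to compound 4 (within the scatter) and no change at the digits printed from compound 3 to compound 4 (within the scatter) and no change at the digits printed from compound 1 to compound 4 (within the scatter) with no exception among the four compounds. With compound 4 at 0% the flat result at this position now extends to a fourth group, so the position still gives no ranking of groups. No measured evidence bears on this result.

On these data alone, whether an amine or a hydroxyl at this aromatic carbon would move the read-out stays open. Also open, as far as these compounds go, is whether an exchange elsewhere on the shared core, such as an amide in place of the carboxylic acid, would do so.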